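A Methyl Shift: 2,4-dimethylphenyl in place of 3,4-dimethylphenyl

This account rests on a few compounds, and the source may have more. Where it says the series, first, only, none or still open, it means among the compounds named here.

Of the compounds shown here, three sharing one core have been measured in a functional assay on HepG2 cells (Homo sapiens) for antiproliferative activity, read by MTT assay, with a stated time of 48 h; a higher number here means a weaker inhibitor, a lower number a stronger inhibitor. Compound 1 `Cc1ccc(NC(=O)Nc2cccc(CNc3nccnc3Cl)c2)cc1C` gives 10700 nM. Compound 2 `Cc1ccc(NC(=O)Nc2cccc(CNc3nccnc3Cl)c2)cc1Cl` gives 11300 nM, and compound 3 `O=C(Nc1ccc(Cl)cc1)Nc1cccc(CNc2nccnc2Cl)c1` gives 8350 nM. Compound 1 stands second highest of the three numbers; its nearest neighbour is compound 2, with a 1.1-fold higher number from compound 1 to compound 2 (0.02 log units; within the scatter), and its furthest is compound 3, with a 1.3-fold lower number from compound 1 to compound 3 (0.11 log units; within the scatter). The remaining pair shows a 1.4-fold lower number from compound 2 to compound 3 (0.13 log units; within the scatter). All three steps lie within the scatter, so this assay does not separate the three compounds.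

Compound 4 `Cc1ccc(NC(=O)Nc2cccc(CNc3nccnc3Cl)c2)c(C)c1` has not yet been measured. It differs from compound 1 only in the group on the amide-type nitrogen: 2,4-dimethylphenyl in place of 3,4-dimethylphenyl on an amide-type nitrogen. Going by the values given here, no measured step tests this exact change, but two steps bear on it, since each alters the group on that same nitrogen: chloro in place of methyl on an aromatic carbon gave a 1.1-fold higher number from compound 1 to compound 2 (0.02 log units; within the scatter), and 4-chlorophenyl in place of 3,4-dimethylphenyl gave a 1.3-fold lower number from compound 1 to compound 3 (0.11 log units; within the scatter), neither beyond the scatter. On that basis one expects no step beyond the scatter for this change either, and the estimated step is a 1.1-fold lower number from compound 1 to compound 4 (0.03 log units; within the scatter). For compound 4 the expected value is 10000 nM, with a range from 4000 nM to 25000 nM.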

Compound 4, half-maximal inhibitory concentration: 9290 nM
The estimate for compound 4 lay 1.1-fold (0.03 log units) above the measured number; measured number inside the range.
By their numbers in this assay, from the lowest: compounds 3, 4, 1 and 2 (each within the scatter of the next).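

In this assay, going by these compounds alone, the swap from 3,4-dimethylphenyl to 2,4-dimethylphenyl on the amide-type nitrogen keeps the same atoms and joins them differently, and it gives a 1.2-fold lower number from compound 1 to compound 4 (0.06 log units; within the scatter); this is the first direct test of rearranging the two methyl groups on this ring, and the rearrangement produces no step beyond the scatter. The two remaining comparisons, a 1.1-fold higher number from compound 3 to compound 4 (0.05 log units; within the scatter) and a 1.2-fold lower number from compound 2 to compound 4 (0.09 log units; within the scatter), also stay within the scatter, so 2,4-dimethylphenyl joins 3,4-dimethylphenyl, 3-chloro-4-methylphenyl and 4-chlorophenyl as groups on this nitrogen that this assay does not separate. Nothing available offers an explanation for this result.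

Going by these compounds, all four compounds carry a phenyl ring bearing only methyl or chloro groups at this position, so it remains open whether a carboxylic acid, an amine or a longer chain such as butyl on that ring would give a step beyond the scatter. The rest of the shared core is identical across the four compounds, which leaves the effect of any change there unknown as well.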